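A few compounds are considered here, and "the series" means these few. Any claim that something is new, unique, unknown or untested is made for them only; others in the source may bear on it.

Compound 2 `COc1ccc(-n2nc(C(=O)Nc3ccc(C)cc3)nc2-c2cc(OC)c(OC)c(OC)c2)cc1` and compound 1 `CCNC(=O)c1nc(-c2cc(OC)c(OC)c(OC)c2)n(-c2ccc(OC)cc2)n1` share the same core and differ only in the group on the amide-type nitrogen. In a functional assay on the whole organism for inhibition, with Rattus norvegicus as the target, read by paw edema, with stated times of 30 min and 3 h, at a dose of 0.28 mmol/kg by the oral route (on this read-out lower numbers stand for less inhibition and higher numbers for more inhibition at the one dose given (going by the name of the read-out)), compound 1 gives 101% and compound 2 gives 88%, the lower of the two numbers, with the step of a number 13 percentage points lower from compound 1 to compound 2 (beyond the scatter) lying beyond the scatter. Compound 3 `COc1ccc(-n2nc(C(=O)Nc3ccc(C(=O)O)cc3)nc2-c2cc(OC)c(OC)c(OC)c2)cc1` has not yet been measured; it differs from compound 2 by carboxy in place of methyl on an aromatic carbon. Within the data shown here, the only measured step, a number 13 percentage points lower from compound 1 to compound 2 (beyond the scatter), concerns the same amide-type nitrogen but a different kind of exchange, so it bears on compound 3 only loosely: it shows that alterations at this end of the molecule can move the read-out by a modest amount. Among the measured compounds shown here, no measured pair shows carboxy in place of methyl. The step to compound 3 is therefore expected to stay small, a number 8 percentage points lower from compound 2 to compound 3 (within the scatter), with more room downward than upward. Compound 3 is estimated to reach 80%, within 55% to 100%.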

Compound 3, a percentage reported as inhibition, in the whole organism at one dose (the size of the read-out at that dose, not a potency): 109%
Estimate against measurement, compound 3: 29 percentage points below; measured number above the stated range.
By their numbers in this assay, from the lowest: compound 2; then compounds 1 and 3 (each within the scatter of the next).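

In this assay, carboxy in place of methyl on the aromatic carbon gives a number 21 percentage points higher from compound 2 to compound 3 (beyond the scatter), so the outer end of the aryl group, and not only the atom on the amide-type nitrogen, can move the read-out. Set against the ethyl group of compound 1, the 4-carboxyphenyl group gives a number 8 percentage points higher from compound 1 to compound 3 (within the scatter), which means that an aryl group here does not always give the lower number seen with compound 2. Nothing measured here explains the change seen with the carboxy group.

Still open, on these data alone, is whether the carboxy group itself matters or other groups at this carbon would serve as well. A methyl ester, an amine or a hydroxymethyl group on the same ring would help separate these possibilities.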